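This account rests on a few compounds, and the source may have more. Where it says the series, first, only, none or still open, it means among the compounds named here.

Measured compounds:
- compound 1, `Cc1nn(C)cc1Nc1nc(N)c2c(C#N)c(N3CCC[C@H]3C)n(C)c2n1`: 1 nM
- compound 2, `Cc1cn(C)nc1Nc1cc2c(c(N)n1)c(C#N)c(N1CCC[C@H]1C)n2C`: 63 nM
- compound 3, `Cn1c(NCc2ccccc2F)c(C#N)c2c(N)ncnc21`: 145 nM

Of the compounds shown here, three have been measured in an assay on isolated protein for binding affinity to Leucine-rich repeat serine/threonine-protein kinase 2 (Homo sapiens), read by TR-FRET and LanthaScreen, with a stated time of 2 h; a higher number here means a weaker inhibitor, a lower number a stronger inhibitor. Compound 1, with the structure `Cc1nn(C)cc1Nc1nc(N)c2c(C#N)c(N3CCC[C@H]3C)n(C)c2n1`, gives 1 nM, the lowest number of the three and therefore the strongest inhibitor in this set. Compound 2, `Cc1cn(C)nc1Nc1cc2c(c(N)n1)c(C#N)c(N1CCC[C@H]1C)n2C`, gives 63 nM, a clearly higher number, and compound 3, `Cn1c(NCc2ccccc2F)c(C#N)c2c(N)ncnc21`, gives 145 nM, the highest of the three. Both gaps to compound 1 are far wider than the scatter of repeated measurements, so compound 1 stands alone at the strong end.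

The next compound, compound 4, has the structure `Cc1n[nH]cc1Nc1nc(N)c2c(C#N)c(N3CCC[C@H]3C)n(C)c2n1`. It differs from compound 1 in a single place: hydrogen in place of methyl on an aromatic nitrogen. For the measured compounds named here, no measured pair in this set shows what this kind of change does, so the expectation rests on compound 1 alone. The change is small, one carbon on an aromatic nitrogen of the pyrazole ring, and the rest of the molecule is untouched. The expected step is a modest weakening, a 3.0-fold higher number from compound 1 to compound 4 (0.48 log units; beyond the scatter), which may well stay within the scatter. Compound 4 is therefore estimated at 3 nM, with a range from 0.7 nM to 12 nM.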

Compound 4, inhibition constant: 1 nM
Estimate against measurement, compound 4: 3.0-fold (0.48 log units) above, and the stated range covers the measured number.
By their numbers in this assay, from the lowest: compounds 1 and 4 (each within the scatter of the next); then compound 2; then compound 3.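

In this assay, hydrogen in place of methyl on an aromatic nitrogen of the five-membered ring gives no change at the digits printed from compound 1 to compound 4 (within the scatter). For the compounds shown here, this is the first pair in the set that differs in one place, and it shows that the low number of compound 1 does not depend on this methyl: going from 1,3-dimethyl-1H-pyrazol-4-yl to 3-methyl-1H-pyrazol-4-yl leaves the reading where it was, so this nitrogen can carry either a methyl or a hydrogen with no change that stands out from the scatter. Nothing here speaks to why the number holds.

On these data alone, only hydrogen and methyl have been seen on this nitrogen, so it remains open how far the tolerance reaches with something larger, such as an ethyl group, a cyclopropyl ring or a longer chain ending in a hydroxyl or an amine. Going by these compounds alone, the methyl on the ring carbon, which stays in place in both compound 1 and compound 4, also remains open, since no pair here shows what hydrogen or a chlorine atom would do in its place.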